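The compounds below may be only part of what the source reports. "The series", "measured", "known", "first", "only" and "open" are said of these compounds alone.

Of the compounds shown here, three with a shared core have been tested in an assay on membranes from HeLa cells for displacement of a labelled ligand from adenosine receptor A3 (Homo sapiens), read by scintillation counting, with a stated time of 180 min, tested at 1 uM; on this read-out higher numbers stand for more inhibition at the one concentration tested (going by the name of the read-out) and lower numbers for less inhibition. Compound 1 `CC1=C(C(=O)C2CC2)C(c2cccs2)NC(=O)N1` gives 15%, compound 2 `CC1=C(C(=O)CC(C)C)C(c2cccs2)NC(=O)N1` gives 18%, and compound 3 `CCC(C)OC(=O)C1=C(C)NC(=O)NC1c1cccs1` gives 7%, the lowest of the three numbers. The step of a number 11 percentage points lower from compound 2 to compound 3 (beyond the scatter) is the only one beyond the scatter, while a number 8 percentage points lower from compound 1 to compound 3 (within the scatter) and a number 3 percentage points higher from compound 1 to compound 2 (within the scatter) are not. Compound 4 `CC1=C(C(=O)OCC2CCC2)C(c2cccs2)NC(=O)N1` differs from compound 3 in one place: cyclobutylmethyl in place of sec-butyl on an oxygen next to a carbonyl group. Among the compounds with values here, no measured step exchanges the group on the oxygen; the measured steps all exchange groups on a carbonyl carbon, so they bear only loosely on this change. The step of a number 3 percentage points higher from compound 3 to compound 4 (within the scatter) that is expected is therefore not beyond the scatter. The estimate for compound 4 in this assay is 10%, between 0% and 25%.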

Compound 4, a percentage reported as inhibition, at one concentration (the size of the read-out at that concentration, not a potency): 1%
The estimate for compound 4 lay 9 percentage points above the measured number, within the range that was stated.
By their numbers in this assay, from the lowest: compounds 4, 3, 1 and 2 (each within the scatter of the next, the first and the last beyond it).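

In this assay, cyclobutylmethyl in place of sec-butyl on an oxygen next to a carbonyl group gives a number 6 percentage points lower from compound 3 to compound 4 (within the scatter), so this exchange on the oxygen does not separate the two groups. On the carbonyl carbon, cyclobutylmethoxy stands clear of both isobutyl, with a number 17 percentage points lower from compound 2 to compound 4 (beyond the scatter), and cyclopropyl, with a number 14 percentage points lower from compound 1 to compound 4 (beyond the scatter), whereas sec-butoxy stood clear of isobutyl alone. No evidence at hand accounts for these differences. The compounds shown leave open whether an amine or a longer chain on that oxygen would move the number beyond the scatter from compound 3.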